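A few compounds are considered here, and "the series" means these few. Any claim that something is new, unique, unknown or untested is made for them only; others in the source may bear on it.

Measured so far:
compound 1, `Cc1ccc([C@@H]2C[C@H](O)Cc3ccccc3N2)s1`, gave 956000 nM;
compound 2, `Cc1ccsc1[C@@H]1C[C@H](O)Cc2ccccc2N1`, gave 616000 nM;
compound 3, `Cc1ccc([C@@H]2C[C@H](O)Cc3cc(OC(F)(F)F)ccc3N2)s1`, gave 23900 nM.

These numbers come from an ADME assay on Vero cells (Chlorocebus sabaeus) for cytotoxicity; on this read-out higher numbers stand for lower toxicity in this test and lower numbers for higher toxicity in this test. Compound 4, `Cc1ccsc1[C@@H]1C[C@H](O)Cc2cc(OC(F)(F)F)ccc2N1`, has not yet been measured in this assay. It differs from compound 3 by 3-methylthiophen-2-yl in place of 5-methylthiophen-2-yl on a saturated ring carbon. The same change, (3-methylthiophen-2-yl in place of 5-methylthiophen-2-yl on a saturated ring carbon), links the two measured compounds without the trifluoromethoxy group, and there it gave the step of a 1.6-fold lower number from compound 1 to compound 2 (0.19 log units; within the scatter). The two cores differ by trifluoromethoxy in place of hydrogen on an aromatic carbon, and that difference produced a large step, a 40-fold lower number from compound 1 to compound 3 (1.60 log units; beyond the scatter). Compound 3 stands far from compounds 1 and 2. The surroundings of the changed place are described in exactly the same words for both pairs, so the change is counted as the same one. Within the data shown here, for compound 4 the step from compound 3 is expected to be about a 1.5-fold lower number from compound 3 to compound 4 (0.17 log units; within the scatter), because the one earlier example, a 1.6-fold lower number from compound 1 to compound 2 (0.19 log units; within the scatter), stayed within the scatter. Compound 3 gives 23900 nM in this assay. On that basis compound 4 is expected to give around 16000 nM, most likely between 6000 nM and 45000 nM.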

Compound 4, half-maximal cytotoxic concentration: 26700 nM
Compound 4: middle estimate off by 1.7-fold (0.22 log units), on the low side; measured number inside the range.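

Swapping 5-methylthiophen-2-yl for 3-methylthiophen-2-yl gives a 1.1-fold higher number from compound 3 to compound 4 (0.05 log units; within the scatter) in this assay, and this small step agrees with the one seen on the core without the trifluoromethoxy group: the same change on two cores in this assay, a 1.6-fold lower number (0.19 log units; within the scatter) from compound 1 to compound 2 and a 1.1-fold higher number (0.05 log units; within the scatter) from compound 3 to compound 4, 1.7-fold (0.24 log units) apart, within the scatter of two such steps. Putting trifluoromethoxy in place of hydrogen gives a 23-fold lower number from compound 2 to compound 4 (1.36 log units; beyond the scatter), so the large step seen with the 5-methylthiophen-2-yl group appears again with the 3-methylthiophen-2-yl group: the same change on two cores in this assay, a 40-fold lower number (1.60 log units; beyond the scatter) from compound 1 to compound 3 and a 23-fold lower number (1.36 log units; beyond the scatter) from compound 2 to compound 4, 1.7-fold (0.24 log units) apart, within the scatter of two such steps. Across these four compounds, each change therefore carried over from one core to the other with much the same size, but this rests on just two examples of each change and does not show that it would hold on any other core, nor does it explain why either step has its size.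

On these data alone, it remains open whether a methoxy group or a chlorine atom on the same aromatic carbon would give a step like that of trifluoromethoxy. As far as these compounds go, it is also open how the number would move with an amine in place of the hydroxy group.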